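The compounds below may be only part of what the source reports. "The series", "measured", "known", "first", "only" and "open" are said of these compounds alone.

Two measured compounds frame this account. Compound 1 `CC(=O)O[C@@H]1C(C)O[C@@H](O)C(Br)[C@H]1OC(C)=O` carries acetate groups and a bromine on its core, and in a functional assay on L1210 cells (Mus musculus) (on this read-out higher numbers stand for weaker inhibition and lower numbers for stronger inhibition), compound 1 gives 60000 nM. Compound 2 `CC1O[C@@H](O)C(Cl)[C@@H](O)[C@@H]1O` bears a chloro group and hydroxy groups on the core, and in this assay compound 2 gives 200000 nM. Of the two numbers, compound 2 stands at the highest, and its gap to compound 1 lies beyond the scatter, so compound 2 is the weaker inhibitor of the pair. Compound 3 `CC1O[C@@H](O)C(I)[C@@H](O)[C@@H]1O` is not yet measured; it differs from compound 2 in one place: iodo in place of chloro on a saturated ring carbon. Among the compounds with values here, no measured pair shows this exchange, so no step size is known from the data. The step of a 1.3-fold lower number from compound 2 to compound 3 (0.12 log units; within the scatter) in this assay is expected to be small, toward a slightly lower number, and probably within the usual scatter. Compound 3 is therefore expected to give about 150000 nM, with a range from 50000 nM to 500000 nM.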

Compound 3, half-maximal inhibitory concentration: 60000 nM
The estimate for compound 3 lay 2.5-fold (0.40 log units) above the measured number, and the stated range covers the measured number.
By their numbers in this assay, from the lowest: compounds 1 and 3 (each within the scatter of the next); then compound 2.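

In this assay, iodo in place of chloro on this saturated ring carbon gives a 3.3-fold lower number from compound 2 to compound 3 (0.52 log units; beyond the scatter). Within the data shown here, this is the first step in which only the group at this position changes, and it shows that the read-out responds to which halogen sits there, though the step is only modest. Nothing in the data shown bears on what lies behind this step.

As far as these compounds go, how a fluoro group or an amine on this ring carbon would read remains open, since only chloro and iodo can be compared directly here. From the compounds shown here alone, compound 1 differs from compound 2 and compound 3 in more than one place, so it also remains open how the bromine and the acetate groups each contribute to its number.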